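The source may hold more compounds than are shown below. What is called first, only, known or untested is meant among the compounds shown, and "the series" means these compounds.

Measured so far in a functional assay on HCT-116 cells (Homo sapiens) for antiproliferative activity, read by MTT assay, with a stated time of 72 h; on this read-out higher numbers stand for weaker inhibition and lower numbers for stronger inhibition:

compound 1 `CCOC(=O)c1csc2nc(CN3CCN(Cc4ccccc4)CC3)c(-c3ccc(C)cc3)n12`: 47800 nM
compound 2 `CCOC(=O)c1csc2nc(CN3CCN(Cc4ccccc4)CC3)c(-c3ccc(OC)cc3)n12`: 19600 nM
compound 3 `CC(=O)NNC(=O)c1csc2ncc(-c3ccc(C)cc3)n12`: 71800 nM

Within the first pair, compound 2 carries methoxy in place of methyl on an aromatic carbon and the step is a 2.4-fold lower number from compound 1 to compound 2 (0.39 log units; beyond the scatter). Compound 3 differs from compound 1 in more than one place; the difference between the two cores is not broken down here. The values of compound 3 and compound 1 lie within the scatter of each other, while compound 2 sits beyond that scatter from both.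

Compound 4 `COc1ccc(-c2cnc3scc(C(=O)NNC(C)=O)n23)cc1` is the not yet measured partner of compound 3: it carries methoxy in place of methyl on an aromatic carbon, the same change as from compound 1 to compound 2, at the same place. Because a 2.4-fold lower number from compound 1 to compound 2 (0.39 log units; beyond the scatter) was modest but beyond the scatter, a step of similar size is expected, a 2.4-fold lower number from compound 3 to compound 4 (0.38 log units; beyond the scatter). Compound 4 is estimated at 30000 nM, expected between 14000 nM and 70000 nM.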

Compound 4, half-maximal inhibitory concentration: 17000 nM
Estimate against measurement, compound 4: 1.8-fold (0.25 log units) above; low and high end bracket the measured number.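

In this assay the step of a 4.2-fold lower number from compound 3 to compound 4 (0.63 log units; beyond the scatter) has the same direction as the step on the core of compound 1, so methoxy in place of methyl on the aromatic carbon carries over between these two cores. The two steps do not differ in size beyond what such steps scatter by: the same change on two cores in this assay, a 2.4-fold lower number (0.39 log units; beyond the scatter) from compound 1 to compound 2 and a 4.2-fold lower number (0.63 log units; beyond the scatter) from compound 3 to compound 4, 1.7-fold (0.24 log units) apart, within the scatter of two such steps. This rests on two pairs only; it does not show that the step would hold on other cores, and it gives no reason for the lower numbers.

Open, going by these compounds, is what chlorine or hydroxy would give on that aromatic carbon. Also open, on these data alone, is whether the step survives with a carboxylic acid in place of the ethyl ester.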